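The source may hold more compounds than are shown below. What is called first, only, known or untested is meant among the compounds shown, and "the series" means these compounds.

Compound 2 `CCC(C)Oc1ccc(C(O)C2OC(=O)c3c(OC)cc(OC)cc32)cc1` is one of two compounds tested in a functional assay on RAW264.7 cells (Mus musculus) for inhibition, read by Griess assay, with stated times of 1 h and 24 h; on this read-out higher numbers stand for weaker inhibition and lower numbers for stronger inhibition. In this assay compound 2 gives > 10000 nM, which is a limit of the assay rather than a number, so it stands only as a limit. Compound 1 `Cc1noc(CC2OC(=O)c3ccccc32)n1` likewise gives > 10000 nM, also a limit. Both values sit at the limit of > 10000 nM in this assay, at which 2 of the 2 values shown sit. Compound 3 `COc1cc(OC)c2c(c1)C(C(O)c1ccc(OCc3ccc(C)cc3)cc1)OC2=O` is not yet measured; it differs from compound 2 by 4-methylbenzyl in place of sec-butyl on an oxygen on an aromatic ring. Going by the values given here, no measured step links these compounds, so no direction beyond the scatter can be expected from the change alone. Compound 3 is therefore expected to give about 15000 nM, within 5000 nM to 50000 nM, most likely again a limit. This estimate implies an expected step that the limit leaves unreadable from compound 2 to compound 3.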

Compound 3, half-maximal inhibitory concentration: 3120 nM
Estimate against measurement, compound 3: 4.8-fold (0.68 log units) above; measured number below the stated range.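

On an oxygen on an aromatic ring, 4-methylbenzyl in place of sec-butyl gives an at least 3.2-fold lower number from compound 2 to compound 3 (0.50 log units; beyond the scatter) in this assay, so this position can respond to a change of group. Compound 3 is also the first compound shown to give a number rather than a limit. The true step may be larger, because compound 2 stands only as a limit: the limit of > 10000 nM in this assay, at which 2 of the 3 values shown sit.

The compounds shown do not tell whether the aromatic ring or the extra carbons account for the step. A plain benzyl group or a longer carbon chain without a ring on the same oxygen would help separate the two.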